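Shifting the Bromine Position of Compound 2

This account rests on a few compounds, and the source may have more. Where it says the series, first, only, none or still open, it means among the compounds named here.

In a functional assay on A549 cells (Homo sapiens) for cytotoxicity, read by sulforhodamine B assay, with a stated time of 48 h (on this read-out lower numbers stand for stronger inhibition and higher numbers for weaker inhibition), compound 2 `O=C(/C=C/c1ccc(Br)cc1)c1cccc(-c2cccc(F)c2)c1` gives 19800 nM. Compound 1 `COc1cc(/C=C/C(=O)c2ccc(N)c(-c3ccc(F)cc3)c2)ccc1O` gives 12200 nM, within the usual scatter of compound 2, and the two share the weak end of these numbers. Compound 3 `COc1ccc(/C=C/C(=O)c2cccc(-c3cccc(F)c3)c2)cc1O` gives 500 nM, a far lower number, well beyond the scatter. Compound 4 `O=C(/C=C/c1cccc(Br)c1)c1cccc(-c2cccc(F)c2)c1`, not yet measured, differs from compound 2 in one place: 3-bromophenyl in place of 4-bromophenyl on a double-bonded chain carbon bound to a double-bonded chain carbon, with 3-bromophenyl in place of 4-bromophenyl on a double-bonded chain carbon bound to a double-bonded chain carbon. For the measured compounds named here, no measured pair shows this change on its own, so the expectation is loose. The expected step of a 1.4-fold lower number from compound 2 to compound 4 (0.15 log units; within the scatter) is slight, toward a lower number, and stays within the scatter. In this assay, compound 4 is estimated at 14000 nM, with a range of 5000 nM to 35000 nM.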

Compound 4, half-maximal inhibitory concentration: 9120 nM
Estimate against measurement, compound 4: 1.5-fold (0.19 log units) above; low and high end bracket the measured number.
By their numbers in this assay, from the lowest: compound 3; then compounds 4, 1 and 2 (each within the scatter of the next, the first and the last beyond it).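

In this assay, for the compounds shown here, the change from 4-bromophenyl to 3-bromophenyl gives a 2.2-fold lower number from compound 2 to compound 4 (0.34 log units; beyond the scatter) and is the first single change here that can be read on its own. With the same atoms joined differently, the number therefore responds to where the bromine sits on this ring, though only modestly. Nothing measured here explains this step.

Still open, on these data alone, is whether chlorine, a nitrile or an amine in place of the bromine would shift the number further. Also open, as far as these compounds go, is whether the same bromine shift holds on a core carrying other groups.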